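A few compounds are considered here, and "the series" means these few. Any claim that something is new, unique, unknown or untested is made for them only; others in the source may bear on it.

Measured compounds:
compound 1, `CCc1ccccc1N(CC(=O)NCc1ccc(Cl)cc1)S(=O)(=O)c1ccc(C)cc1`: 11.5 nM
compound 2, `Cc1ccc(S(=O)(=O)N(CC(=O)NCc2ccc(Cl)cc2)c2ccc(C)nc2)cc1`: < 1450 nM

In a functional assay on CHO-K1 cells for antagonist activity at prostaglandin E2 receptor EP1 subtype (Homo sapiens), read by FLIPR and calcium flux (on this read-out higher numbers stand for weaker inhibition and lower numbers for stronger inhibition), compound 1 gives 11.5 nM. For compound 2 this assay reports only a limit, < 1450 nM, and no number, as recorded in the limit of < 1450 nM in this assay, at which 1 of the 2 values shown sits. The change from compound 1 to compound 2 swaps the group on the sulfonamide nitrogen, but a step that the limit leaves unreadable from compound 1 to compound 2 cannot be read because the limit of < 1450 nM in this assay, at which 1 of the 2 values shown sits, hides the size of that step. Compound 2 therefore stands only as a compound whose inhibition constant lies under a limit, with no exact place among the numbers shown.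

Compound 3, `CCn1nccc1N(CC(=O)NCc1ccc(Cl)cc1)S(=O)(=O)c1ccc(C)cc1`, carries the same core and differs from compound 2 in a single place: 1-ethyl-1H-pyrazol-5-yl in place of 6-methylpyridin-3-yl on a sulfonamide nitrogen. Among the compounds with values here, no measured step bears on this change directly; the one step that touches the sulfonamide nitrogen substituent is unreadable, so the expected direction and size in this assay rest on a wide range rather than on a measured anchor. Compound 3 is estimated to give about 150 nM, with a range from 10 nM to 1450 nM. This amounts to an expected step that the limit leaves unreadable from compound 2 to compound 3, which may itself be unreadable if the assay again reports only a limit.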

Compound 3, inhibition constant: 72.4 nM
Compound 3: the middle estimate sits 2.1-fold (0.32 log units) above what was measured, and the stated range covers the measured number.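

In this assay, the sulfonamide nitrogen now has its first readable step, a 6.3-fold higher number from compound 1 to compound 3 (0.80 log units; beyond the scatter), with 1-ethyl-1H-pyrazol-5-yl in place of 2-ethylphenyl. Within the data shown here, this shows that the position still gives an exact number with a five-membered aromatic ring with 2 hetero atoms, where the only exact value so far came from the 2-ethylphenyl group, and that the exchange costs a modest step that is beyond the scatter. The steps that involve compound 2 cannot be read, because compound 2 is known only through a limit: the limit of < 1450 nM in this assay, at which 1 of the 3 values shown sits.

The compounds shown leave open whether the step follows from the ring itself or from the ethyl group it carries, and a methyl or a propyl chain in place of that ethyl on the same ring would separate the two. They also leave open how a carboxylic acid or an amine on the ring at the sulfonamide nitrogen would read in this assay.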